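Removing the Cyclopentyl Group from Compound 3

The source may report more compounds than this note shows. Statements on the series, on what has been measured and on what is new or still open speak of the compounds shown alone.

In a functional assay on Huh-7 cells (Homo sapiens) for antiproliferative activity, read by CCK-8 assay, with a stated time of 72 h (on this read-out higher numbers stand for weaker inhibition of growth and lower numbers for stronger inhibition of growth), compound 1 `CCCNC(=O)c1ccc2c(ccn2-c2ncc3c(n2)N(c2ccn(C)n2)C(CC)C(=O)N3C)c1` gives 7280 nM and compound 2 `CCC1C(=O)N(C)c2cnc(-n3ccc4cc(C(=O)NCC(C)C)ccc43)nc2N1c1ccn(C)n1` gives 5070 nM as measured values. Compound 3 `CCC1C(=O)N(C)c2cnc(-n3ccc4cc(C(=O)NC5CCCC5)ccc43)nc2N1c1ccn(C)n1` has no number and is reported only as "not active" (no number reported) on this read-out. Compound 4 `CCC1C(=O)N(C)c2cnc(-n3ccc4cc(C(N)=O)ccc43)nc2N1c1ccn(C)n1` differs from it by hydrogen in place of cyclopentyl on an amide-type nitrogen and so carries hydrogen in place of cyclopentyl on an amide-type nitrogen. Among the compounds with values here, the one measured step is a 1.4-fold lower number from compound 1 to compound 2 (0.16 log units; within the scatter) and it adds a methyl to a chain, staying within the scatter. Within the data shown here, it does not size this change, and compound 3 offers no starting number, so no step in this assay can be predicted. The estimate leans on the level of compound 1 at 7280 nM and of compound 2 at 5070 nM instead. Compound 4 is expected near 9000 nM with an estimated range of 3000 nM to 30000 nM if a number is reported.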

Compound 4, concentration for 50% growth inhibition: "not active" (no number reported)
Compound 4: no number reported; no gap can be computed for the estimate.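

Compound 3 and compound 4 are both reported only as "not active" in this assay, so no step can be read between them. Nothing shown offers an explanation for this result. The compounds shown leave open how replacing cyclopentyl with hydrogen on the amide nitrogen affects growth inhibition.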